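A carboxymethyl amide in place of compound 2's side chain

This account rests on a few compounds, and the source may have more. Where it says the series, first, only, none or still open, it means among the compounds named here.

In a functional assay on MCF7 cells (Homo sapiens) for antiproliferative activity, read by MTT assay, with a stated time of 24 h (on this read-out lower numbers stand for stronger inhibition and higher numbers for weaker inhibition), compound 1 `CCn1c(C(=O)NCCC(=O)OC)ccc1C(CC)(CC)c1ccc(OCS(=O)(=O)c2ccccc2)c(C)c1` gives > 50000 nM, which is a limit and not a number. Among the measured compounds shown here, compound 2 `CCn1c(C(=O)N[C@H](CO)CCO)ccc1C(CC)(CC)c1ccc(OCS(=O)(=O)c2ccccc2)c(C)c1` gives 28500 nM, the only actual number so far in this assay. Compound 3 `CCn1c(C(=O)NCC(=O)O)ccc1C(CC)(CC)c1ccc(OCS(=O)(=O)c2ccccc2)c(C)c1` keeps the shared core and carries carboxymethyl in place of 3-hydroxy-1-(hydroxymethyl)propyl on an amide-type nitrogen.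

For the measured compounds named here, one measured step bears on this change, since it concerns the same amide-type nitrogen: an at least 1.7-fold lower number from compound 1 to compound 2 (0.24 log units; that floor lies within the scatter). That step offers only a floor that lies within the scatter, so it gives no firm size for a change at this place. Compound 1, the other compound with a carbonyl in this side chain, ended at the limit, which tilts the expectation slightly towards weaker inhibition. The expected change is small, an estimated 1.4-fold higher number from compound 2 to compound 3 (0.15 log units; within the scatter), and it would not clearly exceed the scatter. For compound 3 the estimated value is 40000 nM, with an expected range of 15000 nM to 90000 nM. A reported limit instead of a number would be no surprise.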

Compound 3, half-maximal inhibitory concentration: 33100 nM
Estimate against measurement, compound 3: 1.2-fold (0.08 log units) above; measured number inside the range.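

Carboxymethyl in place of 3-hydroxy-1-(hydroxymethyl)propyl on the amide-type nitrogen gives a 1.2-fold higher number from compound 2 to compound 3 (0.06 log units; within the scatter) in this assay, so this position now has its first pair of actual numbers, and they cannot be told apart. The side chain can therefore lose the defined stereocentre and change from two hydroxyl groups to a carboxy group with no change in the number that exceeds the scatter. Carboxy in place of (methoxycarbonyl)methyl on a saturated chain carbon bound to an amide-type nitrogen gives an at least 1.5-fold lower number from compound 1 to compound 3 (0.17 log units; that floor lies within the scatter), which is a floor and not a measured size. Compound 1 stands at a value that is a limit and not a number: the limit of > 50000 nM in this assay, at which 1 of the 3 values shown sits.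

Going by these compounds, what remains open is whether any group on this amide-type nitrogen can move the number beyond the scatter, since the two actual numbers in this assay lie within it of each other. A terminal amine on the chain, a benzyl group on the nitrogen, or a carboxylic acid on a longer chain could each put that question to the test.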